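The source may hold more compounds than are shown below. What is called first, only, known or untested is meant among the compounds shown, and "the series" means these compounds.

Measured:
compound 1 `CN(Cc1ccccc1)C(=O)c1nc(Cc2ccccc2C(F)(F)F)n(C)c(=O)c1O` — > 100000 nM
compound 2 `Cn1c(Cc2ccccc2C(F)(F)F)nc(C(=O)NCc2ccccn2)c(O)c1=O` — > 100000 nM

In an ADME assay on HepG2 cells (Homo sapiens) for cytotoxicity, in the presence of a further agent that is not named here (on this read-out lower numbers stand for stronger inhibition and higher numbers for weaker inhibition), compound 1 gives > 100000 nM, which is a limit of the assay. In this assay compound 2 gives > 100000 nM, likewise a limit. The step that the two limits leave unreadable from compound 1 to compound 2 therefore cannot be read. Compound 2 stands at the limit of > 100000 nM in this assay, at which 2 of the 2 values shown sit. Compound 3 `Cn1c(Cc2ccccc2C(F)(F)F)nc(C(=O)NCc2ccccc2)c(O)c1=O` differs from compound 2 by phenyl in place of pyridin-2-yl on a saturated chain carbon bound to an amide-type nitrogen. No measured step bears on this change, and the one step shown is unreadable. Compound 3 is therefore expected to sit where compound 2 sits, with the step that the limit leaves unreadable from compound 2 to compound 3 expected to stay within the scatter. For compound 3 the estimate is 150000 nM, in the range 50000 nM to 500000 nM.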

Compound 3, half-maximal inhibitory concentration: > 100000 nM
Compound 3 gave a limit, no number; the forecaster's own chance of this, stated with the estimate: 80%; the middle value is on the limit's open side.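

In this assay, within the data shown here, compound 3 gives > 100000 nM, a limit, so no step among compound 1, compound 2 and compound 3 can be read. Left open is whether phenyl in place of pyridin-2-yl, or hydrogen in place of methyl on the amide-type nitrogen, changes this read-out at all.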